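Swapping a Diethylamino Tail for a Hydroxy Group

The source may report more compounds than this note shows. Statements on the series, on what has been measured and on what is new or still open speak of the compounds shown alone.

Of the compounds shown here, three sharing one core have been tested in an ADME assay on HEK293 cells (Homo sapiens) for cytotoxicity, read by MTT assay, with a stated time of 48 h; a higher number here means a weaker inhibitor, a lower number a stronger inhibitor. Compound 1 `Cn1c(N)c(-c2nc3ccccc3[nH]2)c2nc(C#N)c(C#N)nc21` carries only hydrogen on the chain carbon bound to the aromatic nitrogen, and in this assay compound 1 sits at the limit of > 50000 nM. Compound 2 `N#Cc1nc2c(-c3nc4ccccc4[nH]3)c(N)n(CCO)c2nc1C#N` carries a 2-hydroxyethyl chain, and compound 2 likewise sits at the limit of > 50000 nM. Going by the values given here, compound 3 `CCN(CC)CCCn1c(N)c(-c2nc3ccccc3[nH]2)c2nc(C#N)c(C#N)nc21` carries a 3-(diethylamino)propyl chain, and compound 3 gives 7870 nM, the only real number in the set. The other two values are limits (the limit of > 50000 nM in this assay, at which 2 of the 3 values shown sit). The steps of an at least 6.3-fold lower number from compound 1 to compound 3 (0.80 log units; beyond the scatter) and an at least 6.3-fold lower number from compound 2 to compound 3 (0.80 log units; beyond the scatter) show that compound 3 stands clearly apart from the other two. The step that the two limits leave unreadable from compound 1 to compound 2 cannot be read, since both ends are limits.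

Compound 4 `N#Cc1nc2c(-c3nc4ccccc4[nH]3)c(N)n(CCCO)c2nc1C#N` differs from compound 3 by hydroxy in place of diethylamino on a saturated chain carbon, three bonds along the chain from an aromatic nitrogen. This undoes the kind of change measured as an at least 6.3-fold lower number from compound 2 to compound 3 (0.80 log units; beyond the scatter), and the closest measured analogue with a hydroxy group, compound 2, gave no number at all. The expectation is therefore a rise in the number, most likely back to the limit. Compound 4 is expected to give about 60000 nM, in a range from 20000 nM to 200000 nM. That estimate corresponds to a step of a 7.6-fold higher number from compound 3 to compound 4 (0.88 log units; beyond the scatter).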

Compound 4, half-maximal inhibitory concentration: > 50000 nM
Compound 4 gave a limit, no number (the forecaster's own chance of this, stated with the estimate: 75%); the middle value lies beyond the limit too.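

With the chain length held fixed, the end group alone now decides the result: in this assay, going from 3-(diethylamino)propyl to 3-hydroxypropyl gives an at least 6.3-fold higher number from compound 3 to compound 4 (0.80 log units; beyond the scatter). The earlier comparison of compound 2 with compound 3 changed the chain length and the end group together, so it could not separate the two, whereas compound 4 shows that a hydroxy group on the same 3-carbon propyl chain does not bring back a measurable number. Among the four compounds shown, a real number therefore appears only with the diethylamino group in place, and the steps among compound 1, compound 2 and compound 4 cannot be read, because all of them end at a limit: the limit of > 50000 nM in this assay, at which 3 of the 4 values shown sit.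

On these data alone, how much of the change depends on the diethylamino group itself remains open, since a smaller amine such as dimethylamino, a morpholine ring or a carboxylic acid at the end of the same propyl chain could separate its contribution from that of the hydroxy group. Also open, as far as these compounds go, is whether the diethylamino group would give a similar number on a shorter ethyl chain or a longer butyl chain.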